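Terminal heteroaryl replacement: triazolyl to isothiazolyl

A few compounds are considered here, and "the series" means these few. Any claim that something is new, unique, unknown or untested is made for them only; others in the source may bear on it.

compound 1 `CCC(C)(C)Cc1c[nH]c(CCc2ccc(-c3cccc(C#N)n3)cc2)n1` — 140 nM
compound 2 `CCC(C)(C)Cc1c[nH]c(CCc2ccc(-n3cncn3)cc2)n1` — 340 nM

Both measured compounds share the core and differ only in the group carried on the aromatic carbon of the six-membered ring of carbon only. In an in vitro assay on CHO cells for displacement of a labelled ligand from Bombesin receptor subtype-3 (Homo sapiens), read by scintillation counting, with a stated time of 2 h (on this read-out lower numbers stand for stronger inhibition and higher numbers for weaker inhibition), compound 1 gives 140 nM and compound 2 gives 340 nM. The step of a 2.4-fold higher number from compound 1 to compound 2 (0.39 log units; beyond the scatter) lies beyond the scatter, so compound 2 stands with the higher of the two numbers. Compound 3 `CCC(C)(C)Cc1c[nH]c(CCc2ccc(-c3ccns3)cc2)n1` differs from compound 2 by 1,2-thiazol-5-yl in place of 1H-1,2,4-triazol-1-yl on an aromatic carbon. Among the compounds with values here, only one measured step bears on this change, a 2.4-fold higher number from compound 1 to compound 2 (0.39 log units; beyond the scatter), where exchanging one ring-linked group for another moved the number modestly. The change to compound 3 is of the same kind, so a modest step in this assay is expected, more likely downward than upward, given that compound 1 with its carbon-linked ring gave 140 nM. For compound 3 the estimate is 220 nM with a range from 90 nM to 550 nM. This corresponds to an expected step of a 1.5-fold lower number from compound 2 to compound 3 (0.19 log units; within the scatter).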

Compound 3, half-maximal inhibitory concentration: 11 nM
For compound 3 the middle estimate is 20-fold (1.30 log units) above the measured one, and the stated range ends above it.
By their numbers in this assay, from the lowest: compound 3; then compound 1; then compound 2.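

In this assay, the group on the aromatic carbon para to a large group can move the number far more than the first pair showed: 1,2-thiazol-5-yl in place of 1H-1,2,4-triazol-1-yl gives a 31-fold lower number from compound 2 to compound 3 (1.49 log units; beyond the scatter) and in place of 6-cyanopyridin-2-yl gives a 13-fold lower number from compound 1 to compound 3 (1.10 log units; beyond the scatter) in the same series. The large step from compound 2 to compound 3 comes with no change in heavy-atom count, so ring size and group size alone do not set the number in this pair. No measurement shown here accounts for the gain.

From the compounds shown here alone, whether it depends on the sulfur, the carbon link or the arrangement of ring atoms stays open; a thiophen-2-yl or 1,3-thiazol-2-yl group would separate these. Also open, going by these compounds, is how an amine or a carboxylic acid on the 1,2-thiazol-5-yl ring would shift the number.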